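This account rests on a few compounds, and the source may have more. Where it says the series, first, only, none or still open, it means among the compounds named here.

The measured compounds and their values:

Compound 1, `CC(C)=CCOc1c(C)c(C)c2c(c1C)CCC(C)(COc1ccc(/C=C3\SC(=O)NC3=O)cc1F)O2`: 95%
Compound 2, `CC(C)=CCOc1c(C)c(C)c2c(c1C)CCC(C)(COc1ccc(/C=C3\SC(=O)NC3=O)cc1C)O2`: 89%
Compound 3, `C=CCOc1c(C)c(C)c2c(c1C)CCC(C)(COc1ccc(/C=C3\SC(=O)NC3=O)cc1C)O2`: 84%

In a functional assay on MCF7 cells (Homo sapiens), tested at 2.5 uM (a higher number here means a weaker effect of the compound at the concentration tested, a lower number a stronger effect), compound 2 gives 89%, the second highest of the three numbers. Its neighbours lie close on either side: a number 6 percentage points lower from compound 1 to compound 2 (within the scatter), and a number 5 percentage points lower from compound 2 to compound 3 (within the scatter). Neither step leaves the usual scatter, so the three compounds cannot be told apart on these numbers.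

Compound 4, `CC(C)=CCOc1c(C)c(C)c2c(c1C)CCC(C)(COc1ccc(/C=C3\SC(=O)NC3=O)cc1-c1ccc(F)cc1)O2`, has not been measured. It differs from compound 2 in one place: 4-fluorophenyl in place of methyl on an aromatic carbon. Within the data shown here, of the two measured steps, only the one from compound 1 to compound 2 touches this same aromatic carbon, and it was a number 6 percentage points lower from compound 1 to compound 2 (within the scatter), within the scatter. The step from compound 2 to compound 3 concerns another part of the molecule and says nothing about this position. The entering group is much larger than anything tried at this carbon so far, so the measured steps give only weak guidance.

Compound 4 is therefore expected to give 85%, with a range from 65% to 100%. The expected step is a number 4 percentage points lower from compound 2 to compound 4 (within the scatter), which is estimated to stay within the scatter, with the wide range reflecting that no measured change of this size at this carbon exists.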

Compound 4, a percentage reported as activity, at one concentration (the size of the read-out at that concentration, not a potency): 87%
The estimate for compound 4 lay 2 percentage points below the measured number; measured number inside the range.
By their numbers in this assay, from the lowest: compounds 3, 4, 2 and 1 (each within the scatter of the next, the first and the last beyond it).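

In this assay, putting 4-fluorophenyl in place of methyl on this aromatic carbon gives a number 2 percentage points lower from compound 2 to compound 4 (within the scatter) and putting it in place of fluoro gives a number 8 percentage points lower from compound 1 to compound 4 (within the scatter) in the same compound series. The earlier compounds shown here had tried only fluoro and methyl here, whereas this group brings 7 heavy atoms and a six-membered aromatic ring of its own, yet neither step leaves the scatter. So far, then, no change at this carbon has produced a step that can be told apart from repeat-measurement noise at this single concentration, even with a much larger group in place. No measurement on hand explains this outcome.

Still open, from the compounds shown here alone, is whether an amine, a carboxylic acid or a longer chain on this carbon would move the number beyond the scatter, since all three groups seen here carry no hydrogen-bond donors or acceptors. Also open, going by these compounds, is whether 4-fluorophenyl here would give a similar number when paired with the vinyl group of compound 3 in place of 2-methylprop-1-en-1-yl.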